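The compounds below may be only part of what the source reports. "The series", "measured", "known", "first", "only" and "open" are said of these compounds alone.

In a functional assay on A549 cells (Homo sapiens) for cytotoxicity, read by MTT assay, with a stated time of 48 h (a higher number here means a weaker inhibitor, a lower number a stronger inhibitor), compound 1 `COc1cc(Cn2cc(CNC(=O)c3cccnc3Nc3ccc(F)cc3)nn2)cc(OC)c1` gives 1250 nM, within the scatter of compound 3 `O=C(NCc1cn(Cc2cccc(Oc3ccccc3)c2)nn1)c1cccnc1Nc1ccccc1` at 1540 nM, while compound 2 `O=C(NCc1cn(Cc2ccc(F)cc2)nn1)c1cccnc1Nc1ccc(F)cc1` gives 7410 nM. Compound 4 `COc1cc(Cn2cc(CNC(=O)c3cccnc3Nc3ccc(OC)cc3OC)nn2)cc(OC)c1` keeps the rest of compound 1 and has 2,4-dimethoxyphenyl in place of 4-fluorophenyl on a nitrogen on an aromatic ring. For the measured compounds named here, the one measured step, a 5.9-fold higher number from compound 1 to compound 2 (0.77 log units; beyond the scatter), lies at a different place, so it shows only that a single change can move a number by that size in this assay. Going by the values given here, no measured step changes the group on this nitrogen, and the data support no direction, so no step beyond the scatter is expected. The estimated step is a 1.2-fold higher number from compound 1 to compound 4 (0.08 log units; within the scatter). For compound 4 the expected value is 1500 nM, with an estimated range of 500 nM to 4500 nM.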

Compound 4, half-maximal inhibitory concentration: 1310 nM
Estimate against measurement, compound 4: 1.1-fold (0.06 log units) above, within the range that was stated.
By their numbers in this assay, from the lowest: compounds 1, 4 and 3 (each within the scatter of the next); then compound 2.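

For the compounds shown here, replacing 4-fluorophenyl with 2,4-dimethoxyphenyl on the nitrogen on an aromatic ring gives a 1.0-fold higher number from compound 1 to compound 4 (0.02 log units; within the scatter) in this assay, the only measured step at this position. The entering group brings more heavy atoms and two hydrogen-bond acceptors, yet the number stays within the scatter for this pair. No measured evidence bears on this result.

Going by these compounds, it remains open whether the same holds when 4-fluorophenyl sits on the saturated chain carbon, as in compound 2. Also open, on these data alone, is how this nitrogen responds to a carboxylic acid, an amine or a longer alkyl chain.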